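Methyl Ester Chain Replaces Ethoxyphenyl on the Amide Nitrogen

The source may hold more compounds than are shown below. What is called first, only, known or untested is meant among the compounds shown, and "the series" means these compounds.

Compound 1 `CCN(CC)CCNC(=O)c1ccc(C(CC)(CC)c2ccc(OCCC(O)(CC)CC)c(C)c2)n1CC` gives 2.3 nM in an assay on cells for agonist activity at vitamin D3 receptor (Homo sapiens), with a stated time of 96 h; on this read-out lower numbers stand for an effect already at smaller amounts and higher numbers for an effect only at larger amounts of compound. Compound 3 `CCOc1ccc(NC(=O)c2ccc(C(CC)(CC)c3ccc(OCCC(O)(CC)CC)c(C)c3)n2CC)cc1` gives 1630 nM in this assay, the highest of the two numbers shown, and a 710-fold higher number from compound 1 to compound 3 (2.85 log units; beyond the scatter). For compound 2 `CCn1c(C(=O)Nc2ccc(OC(F)(F)F)cc2)ccc1C(CC)(CC)c1ccc(OCCC(O)(CC)CC)c(C)c1` the assay reports only a limit, > 10000 nM. Between the two aryl amides, an at least 6.1-fold lower number from compound 2 to compound 3 (0.78 log units; beyond the scatter). Compound 4 `CCC(C)C(NC(=O)c1ccc(C(CC)(CC)c2ccc(OCCC(O)(CC)CC)c(C)c2)n1CC)C(=O)OC` differs from compound 3 by a group of 9 heavy atoms (7 carbon, 2 oxygen; no ring) in place of a group of 9 heavy atoms (8 carbon, 1 oxygen; one six-membered aromatic ring of carbon only), on an amide-type nitrogen. For the measured compounds named here, no measured step covers an open-chain group of this kind on the amide-type nitrogen; the two steps that alter that nitrogen, an at least 4300-fold higher number from compound 1 to compound 2 (3.63 log units; beyond the scatter) and a 710-fold higher number from compound 1 to compound 3 (2.85 log units; beyond the scatter), are both large, so a sizeable move in either direction remains possible. Compound 4 is expected to give about 500 nM, with a range from 50 nM to 5000 nM. The estimated step is a 3.3-fold lower number from compound 3 to compound 4 (0.51 log units; beyond the scatter).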

Compound 4, half-maximal effective concentration: > 10000 nM
Compound 4: only a limit was reported (the forecaster's own chance of this, stated with the estimate: 15%); middle value at least 20-fold (1.30 log units) away from the limit.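

Compound 4 gives only a limit (> 10000 nM) in this assay. There is an at least 6.1-fold higher number from compound 3 to compound 4 (0.78 log units; beyond the scatter) with the open-chain ester group on the amide-type nitrogen, and an at least 4300-fold higher number from compound 1 to compound 4 (3.63 log units; beyond the scatter) with the same change, so an open chain without a ring does not by itself give the low number of compound 1. The step from compound 2 to compound 4 cannot be read, and neither compound can be placed above the other: the limit of > 10000 nM in this assay, at which 2 of the 4 values shown sit.

Open, going by these compounds, is whether a carboxylic acid in place of the methyl ester, or a 2-(dimethylamino)ethyl chain on this nitrogen, would give a low number.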